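Arylidene succinimide amides in a cytotoxicity screen

This account rests on a few compounds, and the source may have more. Where it says the series, first, only, none or still open, it means among the compounds named here.

Measured so far:
Compound 1, `Cc1ccc(NC(=O)c2cccc(/C=C3\CC(=O)N(c4ccccc4)C3=O)c2)cc1C`, in an ADME assay on SW480 cells (Homo sapiens) for cytotoxicity, read by MTT assay, with a stated time of 72 h (a higher number here means a weaker inhibitor, a lower number a stronger inhibitor), gives > 100000 nM, a limit of the assay.
Compound 2, `O=C(Nc1ccc(Cl)cc1)c1cccc(/C=C2\CC(=O)N(Cc3ccccc3)C2=O)c1`, in this assay gives > 100000 nM, a limit of the assay.
Compound 3, `CCCCNC(=O)c1cccc(/C=C2\CC(=O)N(Cc3ccccc3)C2=O)c1`, in this assay gives > 100000 nM, a limit of the assay.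

Compound 1 stands at a limit only, and so do both other measured compounds; no number separates any of the three. Among the compounds with values here, the single one-point step, a step that the two limits leave unreadable from compound 2 to compound 3, is unreadable for the same reason, and the summary of the data is the limit of > 100000 nM in this assay, at which 3 of the 3 values shown sit.

Compound 4, `O=C(Nc1cccc(F)c1)c1cccc(/C=C2\CC(=O)N(c3ccccc3)C2=O)c1`, is not yet measured. It differs from compound 1 in one place: 3-fluorophenyl in place of 3,4-dimethylphenyl on an amide-type nitrogen. Within the data shown here, no measured step covers a change of this kind on the amide-type nitrogen, and the only measured step, butyl in place of 4-chlorophenyl, gave no readable size.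

Among the measured compounds shown here, with every value so far at the limit, the expectation for compound 4 is that it too sits at or around the limit; the step that the limit leaves unreadable from compound 1 to compound 4 is estimated as none beyond the scatter. Compound 4 is therefore expected to give about 150000 nM, within 50000 nM to 500000 nM, most likely reported as a limit again.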

Compound 4, half-maximal inhibitory concentration: > 100000 nM
Compound 4 gave a limit, no number; the forecaster's own chance of this, stated with the estimate: 85%; the middle value does not contradict the limit.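

Compound 1 and compound 4 both stand at a limit of the assay in this assay, so no new step can be read between them, and the summary remains: the limit of > 100000 nM in this assay, at which 4 of the 4 values shown sit.

The compounds shown leave open whether any change on the amide-type nitrogen, or elsewhere on the shared core, gives a numerical value in this assay.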